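A few compounds are considered here, and "the series" means these few. Any claim that something is new, unique, unknown or untested is made for them only; others in the source may bear on it.

Measured in a functional assay on NCI-H1299 cells (Homo sapiens) for antiproliferative activity, read by XTT assay, with a stated time of 72 h; a higher number here means a weaker inhibitor, a lower number a stronger inhibitor:

Compound 1, `COc1ccc(-c2cc3ccccc3nc2/C=C/C(=O)c2ccc(O)cc2)cc1`: 8970 nM
Compound 2, `COc1ccc(-c2cc3ccccc3nc2/C=C/C(=O)c2ccc(OC)cc2OC)cc1`: 3770 nM
Compound 3, `COc1ccc(-c2cc3ccccc3nc2/C=C/C(=O)c2ccc(OC)c(OC)c2)cc1`: 1050 nM

The three compounds share one core and differ only in the ring attached to the carbonyl carbon. Compound 1, which carries the 4-hydroxyphenyl there, stands highest of the three numbers, so it is the weakest inhibitor among them in this assay. Exchanging that ring for a 2,4-dimethoxyphenyl gave a 2.4-fold lower number from compound 1 to compound 2 (0.38 log units; beyond the scatter), and for a 3,4-dimethoxyphenyl an 8.5-fold lower number from compound 1 to compound 3 (0.93 log units; beyond the scatter); between the two dimethoxy patterns the step was a 3.6-fold lower number from compound 2 to compound 3 (0.56 log units; beyond the scatter).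

Compound 4, `COc1ccc(-c2cc3ccccc3nc2/C=C/C(=O)c2ccc([N+](=O)[O-])cc2)cc1`, is the next step from compound 1. The change is nitro in place of hydroxy on an aromatic carbon, at the same ring. Both measured steps away from the hydroxy group lowered the number, which hints that replacing it is tolerated or helpful, but neither introduced a nitro group, so the direction of this particular step is not settled by the data. A modest lowering is therefore expected, with wide uncertainty, as a 2.2-fold lower number from compound 1 to compound 4 (0.35 log units; beyond the scatter). Compound 4 is estimated at 4000 nM, within a range of 1500 nM to 12000 nM.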

Compound 4, half-maximal inhibitory concentration: 770 nM
For compound 4 the middle estimate is 5.2-fold (0.72 log units) above the measured one, outside the stated range (below it).
By their numbers in this assay, from the lowest: compounds 4 and 3 (each within the scatter of the next); then compound 2; then compound 1.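

In this assay the nitro group gives the largest step seen so far at this ring position (a 12-fold lower number from compound 1 to compound 4 (1.07 log units; beyond the scatter)), showing that this place responds strongly to a swap of a single group. It also shows that a low number here does not require methoxy groups: the 4-nitrophenyl ring of compound 4 cannot be told apart from the 3,4-dimethoxyphenyl ring of compound 3 (a 1.4-fold lower number from compound 3 to compound 4 (0.13 log units; within the scatter)), and it clearly outdoes the 2,4-dimethoxyphenyl ring of compound 2 (a 4.9-fold lower number from compound 2 to compound 4 (0.69 log units; beyond the scatter)). Nothing available explains why nitro and hydroxy differ so much at this position.

Going by these compounds, it remains open whether an amine, a carboxylic acid or a nitrile at the same place would give a number closer to that of compound 4 or to that of compound 1. On these data alone, it is also open whether nitro would keep this result at another position on the ring, or whether a nitro group combined with a methoxy group on the same ring would lower the number further.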